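The compounds below may be only part of what the source reports. "The series", "measured", "known", "first", "only" and "open" are said of these compounds alone.

In an ADME assay on HepG2 2.2.15 cells (Homo sapiens) for cytotoxicity (a higher number here means that more compound is tolerated, a lower number that less compound is tolerated), compound 1 `CC(=O)OCC(=O)OCCc1c(-c2ccccc2Cl)c2cc(Cl)ccc2[nH]c1=O` gives 100000 nM as a measured number. Compound 2 `O=C(OCCc1c(-c2ccccc2Cl)c2cc(Cl)ccc2[nH]c1=O)c1cccs1` reads > 1700000 nM in this assay and this is a limit of the assay, not a number. It therefore marks the high end of the two values shown, with no exact position. Going by the values given here, the only measured step is an at least 17-fold higher number from compound 1 to compound 2 (1.23 log units; beyond the scatter) and it puts thiophen-2-yl in place of acetoxymethyl on a carbonyl carbon.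

Compound 3 `O=C(CN1C(=O)c2ccccc2C1=O)OCCc1c(-c2ccccc2Cl)c2cc(Cl)ccc2[nH]c1=O` differs from compound 2 at that same carbonyl carbon, and a group of 12 heavy atoms (9 carbon, 1 nitrogen, 2 oxygen; one five-membered non-aromatic ring with 1 hetero atom, one six-membered aromatic ring of carbon only) in place of a group of 5 heavy atoms (4 carbon, 1 sulfur; one five-membered aromatic ring with 1 hetero atom), on a carbonyl carbon is the whole change. Thiophen-2-yl leaves, so the higher side of that single step is lost. Part of an at least 17-fold higher number from compound 1 to compound 2 (1.23 log units; beyond the scatter) may therefore be given back, though one step is thin support and the new group has not been tested. A move to a lower number is expected, smaller than or similar to that step, and a result near the limit of compound 2 remains possible. The expected step is an at least 6.8-fold lower number from compound 2 to compound 3 (0.83 log units; beyond the scatter) and it is only an estimate. In this assay the expected value for compound 3 is 250000 nM and the estimated range runs from 40000 nM to 1500000 nM overall.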

Compound 3, half-maximal cytotoxic concentration: 960000 nM
Compound 3: the middle estimate sits 3.8-fold (0.58 log units) below what was measured, within the range that was stated.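

In this assay, a high number at this carbonyl carbon turns out not to depend on thiophen-2-yl: the group of 12 heavy atoms, which has no sulfur and no aromatic ring with a hetero atom, also stands well clear of acetoxymethyl, with a 9.6-fold higher number from compound 1 to compound 3 (0.98 log units; beyond the scatter). Set against thiophen-2-yl, the same change reads as an at least 1.7-fold lower number from compound 2 to compound 3 (0.24 log units; that floor lies within the scatter), so the two ring-bearing groups are not firmly separated from each other, and compound 1 alone keeps a clearly lower number among the three. Compound 2 remains a limit of the assay and not a number: the limit of > 1700000 nM in this assay, at which 1 of the 3 values shown sits.

The three groups shown cannot tell whether a ring of any kind at this carbonyl carbon is enough to carry the number upward, or whether it is the loss of the acetoxy part of acetoxymethyl that matters. As far as these compounds go, a plain methyl, a phenyl, a longer alkyl chain or an aminomethyl group at the same place would separate these readings, and how far the thiophen-2-yl and the group of 12 heavy atoms truly lie apart also stays open.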